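Chalcone-type series: replacing pyridin-2-yl with 3-hydroxyphenyl

This account rests on a few compounds, and the source may have more. Where it says the series, first, only, none or still open, it means among the compounds named here.

Measured in a functional assay on HepG2 cells (Homo sapiens) for antiproliferative activity, read by MTT assay, with a stated time of 24 h; a lower number here means a stronger inhibitor, a higher number a weaker inhibitor:
- compound 1 `COc1ccc(C(=O)/C=C/c2cccc([N+](=O)[O-])c2)c2c1C=CC(C)(C)O2` gives 2830 nM
- compound 2 `COc1ccc(C(=O)/C=C/c2cccc(C(F)(F)F)c2)c2c1C=CC(C)(C)O2` gives > 10000 nM
- compound 3 `COc1ccc(C(=O)/C=C/c2ccccn2)c2c1C=CC(C)(C)O2` gives 5760 nM

Compound 3, at 5760 nM, has the higher of the two actual numbers, and the nearest neighbour is compound 1 at 2830 nM. Compound 2 gives > 10000 nM, which is a limit of the assay and not a number.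

Next is compound 4 `COc1ccc(C(=O)/C=C/c2cccc(O)c2)c2c1C=CC(C)(C)O2`, with 3-hydroxyphenyl in place of pyridin-2-yl on a double-bonded chain carbon bound to a double-bonded chain carbon.

Going by the values given here, two measured steps bear on this change. Going from the 3-nitrophenyl of compound 1 to the pyridin-2-yl of compound 3 gave a 2.0-fold higher number from compound 1 to compound 3 (0.31 log units; beyond the scatter), so restoring a substituted phenyl might lower the number in this assay. Against that, changing only the substituent on that phenyl, from compound 1 to compound 2, gave an at least 3.5-fold higher number from compound 1 to compound 2 (0.54 log units; beyond the scatter), so a substituted phenyl does not ensure a number lower than that of compound 3. A small shift towards a lower number is therefore expected, possibly not beyond the scatter. The expected change is a 1.4-fold lower number from compound 3 to compound 4 (0.16 log units; within the scatter).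

For compound 4 the estimated value is 4000 nM, with an expected range of 1400 nM to 10000 nM.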

Compound 4, half-maximal inhibitory concentration: > 10000 nM
Compound 4 gave a limit, no number; the forecaster's own chance of this, stated with the estimate: 15%; middle value at least 2.5-fold (0.39 log units) away from the limit.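

On the phenyl at this place, nitro remains the only substituent shown that gives a readable number in this assay: hydroxy in place of nitro gives an at least 3.5-fold higher number from compound 1 to compound 4 (0.54 log units; beyond the scatter), and trifluoromethyl, in compound 2, had already gone the same way. Restoring a phenyl in place of pyridin-2-yl therefore does not in itself lower the number, as the change gives an at least 1.7-fold higher number from compound 3 to compound 4 (0.23 log units; that floor lies within the scatter), although this floor alone does not separate the two groups by more than the scatter. The step between compound 2 and compound 4 cannot be read, because both values are limits of the assay: the limit of > 10000 nM in this assay, at which 2 of the 4 values shown sit.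

Still open, on these data alone, is how far the true values of compound 2 and compound 4 lie from that limit, and so whether hydroxy and trifluoromethyl differ at all in this assay. As far as these compounds go, it also remains open whether nitro is unusual among substituents on this phenyl, or whether an amine or a carboxylic acid at the same place would also return a readable number.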